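Swapping the amide group of a limit compound

The compounds below may be only part of what the source reports. "The series", "measured", "known", "first", "only" and "open" are said of these compounds alone.

- Compound 1 `CCn1c(C(=O)NCCCN(C)C)ccc1C(CC)(CC)c1ccc(OCCC(O)(CC)CC)c(C)c1`: 490 nM
- Compound 2 `CCn1c(C(=O)NCCN(C)C)ccc1C(CC)(CC)c1ccc(OCCC(O)(CC)CC)c(C)c1`: 1140 nM
- Compound 3 `CCC(C)C(NC(=O)c1ccc(C(CC)(CC)c2ccc(OCCC(O)(CC)CC)c(C)c2)n1CC)C(=O)OC`: > 50000 nM

In a functional assay on Caco-2 cells (Homo sapiens) for antiproliferative activity, read by MTT assay, with a stated time of 48 h (on this read-out higher numbers stand for weaker inhibition and lower numbers for stronger inhibition), compound 3 gives > 50000 nM, which is a limit and not a number. Compound 4 `CCn1c(C(=O)N(C)CCO)ccc1C(CC)(CC)c1ccc(OCCC(O)(CC)CC)c(C)c1` changes one place: a group of 5 heavy atoms (3 carbon, 1 nitrogen, 1 oxygen; no ring) in place of a group of 10 heavy atoms (7 carbon, 1 nitrogen, 2 oxygen; no ring), on a carbonyl carbon. The entering group is (2-hydroxyethyl)(methyl)amino. For the measured compounds named here, two measured steps bear on this, an at least 100-fold higher number from compound 1 to compound 3 (2.00 log units; beyond the scatter) and an at least 43-fold higher number from compound 2 to compound 3 (1.64 log units; beyond the scatter). Both were large, and both changed the group on the amide-type nitrogen. Compound 4 has no dimethylamino group, unlike compound 1 and compound 2, so only part of that size is expected to return, towards a lower number. The expected move is an at least 6.2-fold lower number from compound 3 to compound 4 (0.79 log units; beyond the scatter). In this assay the estimate for compound 4 is 8000 nM, with an expected range of 1500 nM to 40000 nM.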

Compound 4, half-maximal inhibitory concentration: 74 nM
Compound 4: middle estimate off by 110-fold (2.03 log units), on the high side, outside the stated range (below it).
By their numbers in this assay, from the lowest: compound 4; then compound 1; then compound 2. At a limit, above all of these: compound 3.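

In this assay, (2-hydroxyethyl)(methyl)amino on the carbonyl carbon gives a 15-fold lower number from compound 2 to compound 4 (1.19 log units; beyond the scatter) and a 6.6-fold lower number from compound 1 to compound 4 (0.82 log units; beyond the scatter), so a dimethylamino group is not required for a low number at this position. Its size relative to the larger group is only a bound, an at least 670-fold lower number from compound 3 to compound 4 (2.82 log units; beyond the scatter), since compound 3 stands at a limit and not a number: the limit of > 50000 nM in this assay, at which 1 of the 4 values shown sits.

Still open, going by these compounds, is which part of the entering group goes with the lower number, the hydroxyl or the methyl on its nitrogen. On these data alone, how a longer hydroxyalkyl chain or a morpholine on the same carbonyl carbon would read also remains open.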